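The source may hold more compounds than are shown below. What is called first, only, known or untested is meant among the compounds shown, and "the series" means these compounds.

Measured in a functional assay on K562 cells (Homo sapiens), read by MTT assay, with a stated time of 72 h; a lower number here means a stronger inhibitor, a higher number a weaker inhibitor:
Compound 1 `CN(C)c1ncnc2c1c(-c1cc3ccccc3o1)cn2[C@@H]1O[C@H](CO)[C@@H](O)[C@H]1O`: > 20000 nM
Compound 2 `Nc1nc2c(c(-c3ccoc3)cn2[C@@H]2O[C@H](CO)[C@@H](O)[C@H]2O)c(=O)[nH]1`: 12500 nM

The entry for compound 1, > 20000 nM, is a limit of the assay and not a number. Among the measured compounds shown here, compound 2, at 12500 nM, therefore holds the only true number so far, and it stands as a weak inhibitor in this assay.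

Compound 3 `Nc1nc2c(c(-c3ccccc3)cn2[C@@H]2O[C@H](CO)[C@@H](O)[C@H]2O)c(=O)[nH]1` carries phenyl in place of furan-3-yl on an aromatic carbon. For the measured compounds named here, no measured step shows what such a change does, so the expectation rests on the value of compound 2, 12500 nM. No shift beyond the scatter is expected. The expected change is a 1.4-fold higher number from compound 2 to compound 3 (0.16 log units; within the scatter). For compound 3 the estimated value is 18000 nM, with an expected range of 7000 nM to 40000 nM.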

Compound 3, half-maximal inhibitory concentration: > 20000 nM
Compound 3 gave a limit, no number; the forecaster's own chance of this, stated with the estimate: 40%; middle value at least 1.1-fold (0.04 log units) away from the limit.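

At this aromatic carbon, phenyl in place of furan-3-yl gives an at least 1.6-fold higher number from compound 2 to compound 3 (0.20 log units; that floor lies within the scatter) in this assay. Among the compounds shown here, this is the first step read at this position, and it shows that the six-membered carbon ring does not give a stronger inhibitor than furan-3-yl. The value of compound 3 is a limit of the assay and not a number, so the step can be read only as a floor: the limit of > 20000 nM in this assay, at which 2 of the 3 values shown sit.

The compounds shown leave open how far compound 3 really lies from compound 2. They also leave open whether a smaller group at this carbon, such as an amine or a thiophene ring, would give a stronger inhibitor.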